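The source may hold more compounds than are shown below. What is called first, only, known or untested is meant among the compounds shown, and "the series" means these compounds.

Measured so far in an in vitro functional assay on HEK285-7 cells for antagonist activity at prostaglandin D2 receptor 2 (Homo sapiens), read by BRET and beta-arrestin recruitment; on this read-out lower numbers stand for stronger inhibition and higher numbers for weaker inhibition:
- compound 1, `O=C(O)Cc1sc(CS(=O)(=O)c2ccc(Cl)cc2)nc1-c1ccc(Cl)cc1`: 730 nM
- compound 2, `O=C(O)Cc1sc(C(c2ccccc2)c2ccc(Cl)cc2)nc1-c1ccc(Cl)cc1`: 75 nM

Compound 2 stands lowest of the two numbers, and compound 1 is the nearest; the number for compound 1 is higher, and the gap lies beyond the scatter. For the measured compounds named here, no single-change step links the two measured structures, so the pair shows only that the two values differ in this way.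

The next structure, compound 3, `O=C(O)Cc1sc(C(c2ccccc2)c2ccccn2)nc1-c1ccc(Cl)cc1`, follows from compound 2 by one change: pyridin-2-yl in place of 4-chlorophenyl on a saturated chain carbon bound to two aromatic carbons. The saturated chain carbon bound to two aromatic carbons keeps one phenyl, and the second aromatic ring changes as described.

Going by the values given here, no measured step in this assay covers such a change, so the expectation rests on compound 2 alone. A modest shift toward a higher number is expected from compound 2 to compound 3, a 2.4-fold higher number from compound 2 to compound 3 (0.38 log units; beyond the scatter), of a size near the edge of the scatter rather than clearly beyond it. Compound 3 is therefore estimated at 180 nM in this assay, with a range from 60 nM to 600 nM.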

Compound 3, half-maximal inhibitory concentration: 1900 nM
For compound 3 the middle estimate is 11-fold (1.02 log units) below the measured one; the measured number lies above the stated range.
By their numbers in this assay, from the lowest: compound 2; then compound 1; then compound 3.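

In this assay, for the compounds shown here, the saturated chain carbon bound to two aromatic carbons proves highly sensitive to the identity of the second aromatic ring: pyridin-2-yl in place of 4-chlorophenyl gives a 25-fold higher number from compound 2 to compound 3 (1.40 log units; beyond the scatter) and this large step is the first single-change reading, something the earlier pair, which differs in more than one place, could not provide. The change is also a composite one, since the chlorine leaves, a ring of carbon only gives way to a ring with one hetero atom, and one hydrogen-bond acceptor enters, so this single step cannot assign the loss to any one of these differences. Nothing available on these compounds bears on the reason for the step.

Still open, going by these compounds, is how much of the step follows the loss of chlorine and how much the ring nitrogen, a question that an unsubstituted phenyl or a chloropyridinyl ring at this carbon would address. Also open, on these data alone, is whether the outcome is specific to pyridin-2-yl or extends to pyridin-3-yl and pyridin-4-yl.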